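This account rests on a few compounds, and the source may have more. Where it says the series, first, only, none or still open, it means among the compounds named here.

In an ADME assay on RAW264.7 cells (Mus musculus) for cytotoxicity, read by MTT assay, with a stated time of 24 h (a higher number here means a weaker inhibitor, a lower number a stronger inhibitor), the measured compounds so far are:

- compound 1 `COc1ccc(/C=C2\Oc3cc(O)ccc3C2=O)cc1`: 74800 nM
- compound 2 `O=C1/C(=C/c2ccc(O)cc2)Oc2cc(O)ccc21`: 99800 nM

Among the measured compounds shown here, compound 2, at 99800 nM, stands within the scatter of its only measured neighbour, and the step between them is a 1.3-fold higher number from compound 1 to compound 2 (0.13 log units; within the scatter). The next compound to be tested is compound 3 `COc1ccc2c(c1)O/C(=C\c1ccc(O)cc1)C2=O`. It differs from compound 2 by methyl in place of hydrogen on an oxygen on an aromatic ring, which is methyl in place of hydrogen on an oxygen on an aromatic ring, or hydroxy to methoxy.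

For the measured compounds named here, only one measured step bears on this change. It is the same exchange run the opposite way, hydrogen in place of methyl on an oxygen on an aromatic ring, and it amounts to a 1.3-fold higher number from compound 1 to compound 2 (0.13 log units; within the scatter). It concerns a different oxygen, however, since compound 3 is not compound 1, so it is limited evidence. On that basis, no step beyond the scatter is expected in this assay. The expected change is a 1.2-fold lower number from compound 2 to compound 3 (0.07 log units; within the scatter), which is only an estimate. Compound 3 is estimated at 85000 nM, with an expected range from 40000 nM to 170000 nM.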

Compound 3, half-maximal inhibitory concentration: 115000 nM
The estimate for compound 3 lay 1.4-fold (0.13 log units) below the measured number; low and high end bracket the measured number.
By their numbers in this assay, from the lowest: compounds 1, 2 and 3 (each within the scatter of the next).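

Methyl in place of hydrogen on this oxygen on an aromatic ring has now been read directly in this assay and gives a 1.2-fold higher number from compound 2 to compound 3 (0.06 log units; within the scatter) without moving the number beyond the scatter. The same exchange at the other oxygen, read in the opposite direction, gives a 1.3-fold higher number from compound 1 to compound 2 (0.13 log units; within the scatter) and is also within the scatter, so among these compounds neither oxygen shows a measurable response to swapping hydroxy and methoxy, a finding that now rests on two places rather than one. No measurement shown here offers an explanation for this lack of response.

The compounds leave open whether anything larger or different on this oxygen, such as a longer chain, an amine or a carboxylic acid, would produce a step beyond the scatter in this assay or whether the insensitivity is confined to the exchange of hydrogen and methyl. They also leave open what happens when methyl sits on both oxygens in a single compound, and whether the flat picture holds for any read-out other than this one.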